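A few compounds are considered here, and "the series" means these few. Any claim that something is new, unique, unknown or untested is made for them only; others in the source may bear on it.

Of the compounds shown here, two share a core and have been tested in a functional assay on SK-MEL-2 cells (Homo sapiens) for cytotoxicity, read by sulforhodamine B assay, with a stated time of 48 h; on this read-out higher numbers stand for weaker inhibition of growth and lower numbers for stronger inhibition of growth. Compound 1, with the structure `Nc1nc(Cl)c2ncn(Cc3ccc(CCl)cc3)c2n1`, carries an amino group on the core and a chloromethyl group on the benzyl ring; in this assay compound 1 gives 28800 nM. Compound 2, with the structure `ClCc1cccc(Cn2cnc3nc(Cl)nc(Cl)c32)c1`, carries two chloro groups on the core and a chloromethyl group on the benzyl ring at a different position; in this assay compound 2 gives 3710 nM. Compound 2 thus stands at the lowest of the two numbers, with compound 1 showing a number higher by a gap that lies beyond the usual scatter. For the measured compounds named here, no two measured compounds differ in a single place, so no measured step is available.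

Compound 3, with the structure `ClCc1cccc(Cn2cnc3ncnc(Cl)c32)c1`, differs from compound 2 in one place: hydrogen in place of chloro on an aromatic carbon. The change is small in size. For compound 3 a modest weakening is expected, of the size a 1.8-fold higher number from compound 2 to compound 3 (0.24 log units; within the scatter), possibly no more than the scatter. Compound 3 is estimated at 6500 nM, with a range from 2000 nM to 20000 nM.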

Compound 3, concentration for total growth inhibition: 22900 nM
The estimate for compound 3 lay 3.5-fold (0.55 log units) below the measured number; measured number outside the range, above it.
By their numbers in this assay, from the lowest: compound 2; then compounds 3 and 1 (each within the scatter of the next).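

In this assay, putting hydrogen in place of the chloro group on the aromatic carbon between two ring nitrogen atoms gives a 6.2-fold higher number from compound 2 to compound 3 (0.79 log units; beyond the scatter). Compounds 1 and 2 differ in more than one place, so their gap could not be tied to any single change, whereas this step ties a difference beyond the usual scatter to this one position: a change of one chlorine atom, with the rest of the structure unchanged, is enough to weaken growth inhibition. Nothing measured here explains why this chloro group matters, so the step records an effect without giving its cause.

From the compounds shown here alone, with only chloro and hydrogen seen at this position, it remains open whether another group there, such as a bromo group, a methoxy group or an amine, would give a number nearer to that of compound 2 or that of compound 3. Going by these compounds, the step also says nothing about the chloromethyl group on the benzyl ring, so it remains open how a plain methyl or a hydroxymethyl group in its place would read out.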